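The compounds below may be only part of what the source reports. "The series", "measured", "known", "first", "only" and "open" are said of these compounds alone.

Measured compounds and their values:

Compound 1 `COc1ccc(CN(C(=O)C2CC2)c2cc(OC)c(OC)c(OC)c2)cc1O` gives 80 nM in a functional assay on KYSE-450 cells (Homo sapiens) for inhibition, read by MTT assay, with a stated time of 48 h; on this read-out higher numbers stand for weaker inhibition and lower numbers for stronger inhibition.
Compound 2 `COc1ccc(CN(C(=O)CN=[N+]=[N-])c2cc(OC)c(OC)c(OC)c2)cc1O` gives 160 nM.
Compound 3 `C/C=C/C(=O)N(Cc1ccc(OC)c(O)c1)c1cc(OC)c(OC)c(OC)c1` gives 67 nM.

The three compounds share one core and differ only in the group attached to the carbonyl carbon of the amide. Compound 3 shows the lowest of the three numbers, yet its separation from compound 1 is small: the change is a 1.2-fold lower number from compound 1 to compound 3 (0.08 log units; within the scatter), which leaves the two indistinguishable here. Against compound 2 the gap is wider, a 2.4-fold lower number from compound 2 to compound 3 (0.38 log units; beyond the scatter). The remaining comparison, a 2.0-fold higher number from compound 1 to compound 2 (0.30 log units; within the scatter), also stays within the usual scatter.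

Compound 4 `COc1ccc(CN(C(=O)C(C)Br)c2cc(OC)c(OC)c(OC)c2)cc1O` is the next variation at the same position. Its difference from compound 3 is 1-bromoethyl in place of prop-1-en-1-yl on a carbonyl carbon. All three measured steps bear on this change, since each swaps one group on that carbonyl carbon for another, and none of them moved the number by more than a modest amount. On that basis a step of a 1.5-fold higher number from compound 3 to compound 4 (0.17 log units; within the scatter) in this assay is expected for compound 4, meaning no clear shift beyond the scatter. Compound 4 is therefore estimated at 100 nM, with a range from 40 nM to 300 nM.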

Compound 4, half-maximal inhibitory concentration: 160 nM
The estimate for compound 4 lay 1.6-fold (0.20 log units) below the measured number; the range from low to high includes it.
By their numbers in this assay, from the lowest: compounds 3, 1, 2 and 4 (each within the scatter of the next, the first and the last beyond it).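

In this assay, the change from prop-1-en-1-yl to 1-bromoethyl on the carbonyl carbon gives a 2.4-fold higher number from compound 3 to compound 4 (0.38 log units; beyond the scatter), so a second group now stands beyond the scatter from the prop-1-en-1-yl amide. The 1-bromoethyl group cannot be told apart from azidomethyl, with no change at the digits printed from compound 2 to compound 4 (within the scatter), or from cyclopropyl, with a 2.0-fold higher number from compound 1 to compound 4 (0.30 log units; within the scatter). Across these four compounds the position therefore spans only a modest range, and compound 1 lies within the scatter of all the others, so it goes against any clean split of the groups into two sets. Nothing in the information available explains the step from compound 3 to compound 4.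

The compounds shown leave open whether a plain ethyl or a 1-chloroethyl group on this carbonyl carbon would read like compound 3 or like compound 4, which would separate the loss of the double bond from the arrival of the bromine. They also leave open whether an amine, a carboxylic acid or a longer chain at this place would move the number further than any step seen here.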